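The source may hold more compounds than are shown below. What is called first, only, known or untested is meant among the compounds shown, and "the series" means these compounds.

Among the compounds with values here, in a functional assay on the whole organism with Rattus norvegicus as the target (on this read-out higher numbers stand for an effect only at larger amounts of compound and lower numbers for an effect already at smaller amounts), compound 1 `CCCCn1c(=N)sc2cc(OC(F)(F)F)ccc21` gives 10 mg/kg and compound 2 `CS(=O)(=O)CCCn1c(=N)sc2cc(OC(F)(F)F)ccc21` gives 5 mg/kg on the only two numbers available, which leaves compound 2 level with compound 1 within the scatter. Compound 3 `CN(C)CCn1c(=N)sc2cc(OC(F)(F)F)ccc21` departs from compound 2 through dimethylamino in place of (methylsulfonyl)methyl on a saturated chain carbon, two bonds along the chain from an aromatic nitrogen on the same chain. Within the data shown here, the sole measured step is a 2.0-fold lower number from compound 1 to compound 2 (0.30 log units; within the scatter) and it involves no dimethylamino group, so it bears only loosely on this change. No step beyond the scatter is therefore expected in this assay here. The expected step is a 1.4-fold higher number from compound 2 to compound 3 (0.15 log units; within the scatter) and no more. For compound 3 the estimate is 7 mg/kg with an expected range from 2.5 mg/kg to 20 mg/kg around it.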

Compound 3, dose for half-maximal effect: 2.3 mg/kg
Beside the measured number, compound 3's estimate is 3.0-fold (0.48 log units) above it; the measured number lies below the stated range.
By their numbers in this assay, from the lowest: compound 3; then compounds 2 and 1 (each within the scatter of the next).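

In this assay, within the data shown here, dimethylamino at this place gives the first changes beyond the scatter, though both are modest: a 2.2-fold lower number from compound 2 to compound 3 (0.34 log units; beyond the scatter), and a 4.3-fold lower number from compound 1 to compound 3 (0.64 log units; beyond the scatter). Among these compounds, the earlier compounds showed only a step within the scatter, so a 2-(dimethylamino)ethyl chain is the first to separate from the others on this read-out. Nothing available accounts for this difference. The compounds shown leave open whether the amine or the chain length carries the step, since 3-(methylsulfonyl)propyl gives way to 2-(dimethylamino)ethyl in a single change. A 3-(dimethylamino)propyl chain, or a pyrrolidine or morpholine in place of dimethylamino, would bear on this.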